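Swapping a sulfonyl group for an acetyl on an aniline

This account rests on a few compounds, and the source may have more. Where it says the series, first, only, none or still open, it means among the compounds named here.

Measured compounds:
- compound 1, `COc1ccc(N)cc1-c1cnc2[nH]cc(-c3ccncc3)c2c1`: 110 nM in an assay on isolated protein for inhibition of high affinity nerve growth factor receptor (Homo sapiens), read by 33P incorporation; on this read-out higher numbers stand for weaker inhibition and lower numbers for stronger inhibition
- compound 2, `CC(=O)Nc1cccc(-c2cnc3[nH]cc(-c4ccncc4)c3c2)c1`: in this assay compound 2 gives 34.3 nM
- compound 3, `Nc1cc(NS(=O)(=O)c2ccccc2)cc(-c2cnc3[nH]cc(-c4ccncc4)c3c2)c1`: in this assay compound 3 gives 9.4 nM

Three compounds share a common core and differ only in the substituents on the pendant phenyl ring. In this assay compound 3 stands at the lowest number of the three, and both gaps to it lie beyond the usual scatter: compound 2 sits higher, and compound 1 sits higher still. Compound 3 is therefore the strongest inhibitor among the measured set.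

Compound 4, `CC(=O)Nc1cc(N)cc(-c2cnc3[nH]cc(-c4ccncc4)c3c2)c1`, has not yet been measured. Relative to compound 3 it carries acetyl in place of phenylsulfonyl on a nitrogen on an aromatic ring, while the amino group on the same ring stays in place. For the measured compounds named here, no measured pair isolates this exact change, so the expectation rests on the neighbours: compound 2 carries an acetamido group alone and gives 34.3 nM, a higher number than compound 3. On that basis compound 4 is expected to land somewhere between compound 3 and compound 2, with a step of a 2.7-fold higher number from compound 3 to compound 4 (0.42 log units; beyond the scatter) expected towards weaker inhibition, larger than the scatter but short of the full distance to compound 2. The estimate for compound 4 is 25 nM, with a likely range from 8 nM to 80 nM.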

Compound 4, half-maximal inhibitory concentration: 5.41 nM
Compound 4: middle estimate off by 4.6-fold (0.66 log units), on the high side, outside the stated range (below it).
By their numbers in this assay, from the lowest: compounds 4 and 3 (each within the scatter of the next); then compound 2; then compound 1.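

In this assay, exchanging phenylsulfonyl for acetyl on the nitrogen on the aromatic ring gives a 1.7-fold lower number from compound 3 to compound 4 (0.24 log units; within the scatter), so with the amino group in place the two groups cannot be told apart, and the six-membered aromatic ring of the phenylsulfonyl group is not needed to keep inhibition at this level. For the compounds shown here, the amino group, whose contribution no earlier pair could isolate, now has a step of its own: with the acetamido group held constant, amino in place of hydrogen on an aromatic carbon gives a 6.3-fold lower number from compound 2 to compound 4 (0.80 log units; beyond the scatter) in this assay, a modest change beyond the scatter towards stronger inhibition. Nothing at hand explains why the acetyl group does as well as the larger group or why the amino group adds inhibition.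

The compounds shown leave open whether the amino group brings a similar step when phenylsulfonyl sits on the other nitrogen, since no partner of compound 3 without the amino group appears among them. They also leave open how a methanesulfonyl group or a longer acyl chain such as butanoyl would compare on that nitrogen, and whether a hydroxyl group could take the place of the amino group.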